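A few compounds are considered here, and "the series" means these few. Any claim that something is new, unique, unknown or untested is made for them only; others in the source may bear on it.

Measured so far in an assay on Sf9 cells for inhibition of protein deacetylase HDAC6 (Homo sapiens), read by fluorescence, with a stated time of 40 min, tested at 100 nM; on this read-out higher numbers stand for more inhibition at the one concentration tested (going by the name of the read-out) and lower numbers for less inhibition:
compound 1 `O=C(NO)c1ccc(NCc2nc(-c3cccc(Cl)c3)nn2-c2ccccc2)cc1` gives 61.2%
compound 2 `Nc1ccccc1NC(=O)c1ccc(NCc2nc(-c3ccccc3)nn2-c2ccccc2)cc1` gives 5%
compound 3 `NC(=O)c1ccc(NCc2nc(-c3ccccc3)nn2-c2ccccc2)cc1` gives -4.4%

Compound 1 stands highest of the three, beyond the scatter above both compound 2 and compound 3, which sit close to each other. Among the compounds with values here, the one measured step, a number 9.4 percentage points lower from compound 2 to compound 3 (within the scatter), concerns an amide-type nitrogen and not the ring carbon altered here, so it does not bear on the move from compound 1 to compound 4 `CC(C)c1ccc(-c2nc(CNc3ccc(C(=O)NO)cc3)n(-c3ccccc3)n2)cc1`. That move is 4-isopropylphenyl in place of 3-chlorophenyl on an aromatic carbon. Within the data shown here, no measured pair speaks to a change at this aromatic carbon, so the data give no direction; the expected step is a number 6.2 percentage points lower from compound 1 to compound 4 (within the scatter), nothing beyond the scatter. Compound 4 is therefore estimated at about 55% in this assay, with a range from 25% to 85%.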

Compound 4, a percentage reported as inhibition, at one concentration (the size of the read-out at that concentration, not a potency): 27.6%
Beside the measured number, compound 4's estimate is 27.4 percentage points above it, and the stated range covers the measured number.
By their numbers in this assay, from the lowest: compounds 3 and 2 (each within the scatter of the next); then compound 4; then compound 1.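

In this assay, within the data shown here, the group on this aromatic carbon turns out to matter, which no earlier pair could show: placing 4-isopropylphenyl there instead of 3-chlorophenyl gives a number 33.6 percentage points lower from compound 1 to compound 4 (beyond the scatter). Among these compounds, changing only this group is enough to move the inhibition by more than the usual scatter. No measurement shown accounts for the size of this drop.

This step changes both the substituent on the phenyl ring and its ring position, and the compounds shown do not separate the two. A 4-chlorophenyl or a 3-isopropylphenyl group at this carbon would bear directly on that question.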